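Ethyl on the Benzoyl Ring: Compound 1 to Compound 4

A few compounds are considered here, and "the series" means these few. Any claim that something is new, unique, unknown or untested is made for them only; others in the source may bear on it.

Compound 1 `CCN1CCN(c2cc(C)c3cc(NC(=O)c4ccccc4)ccc3n2)CC1`: 18400 nM
Compound 2 `Cc1cc(N2CCCCC2)nc2ccc(NC(=O)c3ccc(Cl)c(Cl)c3)cc12`: 42500 nM
Compound 3 `Cc1cc(N2CCN(C(C)C)CC2)nc2ccc(NC(=O)c3ccc(Cl)c(Cl)c3)cc12`: 6680 nM

In a functional assay on SK-BR-3 cells (Homo sapiens) for antiproliferative activity, read by MTT assay, with a stated time of 72 h (on this read-out higher numbers stand for weaker inhibition and lower numbers for stronger inhibition), compound 1 gives 18400 nM, the second highest of the three numbers: compound 2 sits higher at 42500 nM, compound 3 lower at 6680 nM. Compound 4 `CCc1ccc(C(=O)Nc2ccc3nc(N4CCN(CC)CC4)cc(C)c3c2)cc1` differs from compound 1 by ethyl in place of hydrogen on an aromatic carbon. For the measured compounds named here, the only step measured, a 6.4-fold lower number from compound 2 to compound 3 (0.80 log units; beyond the scatter), changes the other end of the molecule and does not bear on the benzoyl ring, so the account has no direct precedent for this change. Going by the values given here, compounds 1 and 3 differ in two places, so their values show only that a substituted benzoyl ring can go with a lower number. A small step downward, within or near the scatter, is expected for compound 4, a 1.5-fold lower number from compound 1 to compound 4 (0.19 log units; within the scatter). Compound 4 is estimated at 12000 nM, between 4500 nM and 32000 nM.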

Compound 4, half-maximal inhibitory concentration: 9850 nM
Compound 4: middle estimate off by 1.2-fold (0.09 log units), on the high side; the measured number falls inside the stated range.
By their numbers in this assay, from the lowest: compounds 3, 4 and 1 (each within the scatter of the next, the first and the last beyond it); then compound 2.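

In this assay, for the compounds shown here, the only single change measured on the benzoyl ring, ethyl in place of hydrogen, para to a large group, gives a 1.9-fold lower number from compound 1 to compound 4 (0.27 log units; within the scatter). Going by these compounds alone, this place on the ring therefore takes an ethyl without a step beyond the scatter, which the earlier compounds could not show. Nothing at hand explains this result or ties it to any property of the ethyl group. The compounds shown leave open how an amine, a carboxylic acid or a longer chain at this same place would read.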